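A few compounds are considered here, and "the series" means these few. Any claim that something is new, unique, unknown or untested is made for them only; others in the source may bear on it.

Measured in an ADME assay on HEK-293T cells (Homo sapiens) for cytotoxicity, read by MTT assay, with a stated time of 48 h; a lower number here means that less compound is tolerated, a higher number that more compound is tolerated:
compound 1 `Cc1ccc(-n2cc(NC(=O)c3cccc(NS(=O)(=O)c4ccccc4)c3)cn2)cc1` gives 93800 nM
compound 2 `Cc1ccc(-n2cc(NC(=O)c3cccc(NS(=O)(=O)c4ccc(Cl)cc4)c3)cn2)cc1` gives 110000 nM
compound 3 `Cc1ccc(-n2cc(NC(=O)c3ccc(NS(=O)(=O)c4ccccc4)cc3)cn2)cc1` gives 107000 nM

Compound 4 `Cc1ccc(-n2cc(NC(=O)c3ccc(NS(=O)(=O)c4ccc(Cl)cc4)cc3)cn2)cc1` has not yet been measured in this assay.

All three measured numbers lie close together, and none of the gaps between them is beyond the usual scatter of this kind of measurement. From compound 1 to compound 2 the change is chloro in place of hydrogen on an aromatic carbon, and the step it made is a 1.2-fold higher number from compound 1 to compound 2 (0.07 log units; within the scatter). The cores of compound 1 and compound 3 are built from the same atoms joined differently; that difference between the two cores is not broken down here. Compound 4 carries the same change on the core of compound 3: chloro in place of hydrogen on an aromatic carbon. The surroundings of the place are described in identical words for both pairs, so this is the same change, made a second time on a different core.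

Among the measured compounds shown here, the expectation for compound 4 rests on the one measured instance of this change, a 1.2-fold higher number from compound 1 to compound 2 (0.07 log units; within the scatter), which lies within the scatter. The step from compound 3 to compound 4 in this assay is therefore expected to be small as well, a 1.1-fold higher number from compound 3 to compound 4 (0.05 log units; within the scatter). For compound 4 in this assay the estimated value is 120000 nM, with a likely range from 60000 nM to 240000 nM.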

Compound 4, half-maximal cytotoxic concentration: 138000 nM
The estimate for compound 4 lay 1.2-fold (0.06 log units) below the measured number; the measured number falls inside the stated range.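

In this assay, chloro in place of hydrogen on the core of compound 3 gives a 1.3-fold higher number from compound 3 to compound 4 (0.11 log units; within the scatter). Set beside the earlier instance, the change shows no measurable dependence on which of the two cores carries it: the same change on two cores in this assay, a 1.2-fold higher number (0.07 log units; within the scatter) from compound 1 to compound 2 and a 1.3-fold higher number (0.11 log units; within the scatter) from compound 3 to compound 4, 1.1-fold (0.04 log units) apart, within the scatter of two such steps. Among the compounds shown here, this shows only that the change stayed within the scatter on both cores, so the agreement is between two small steps and does not establish a real effect of chloro on either core, nor does it show that a change with a larger step would carry across in the same way.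

Open, on these data alone, is whether another group at this same place on the six-membered aromatic ring, such as an amine, a carboxylic acid or a longer chain, would give a step beyond the scatter in this assay. Also open, as far as these compounds go, is how the series responds to replacing the methyl group common to all four compounds.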